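The source may report more compounds than this note shows. Statements on the series, on what has been measured and on what is new or still open speak of the compounds shown alone.

Measured compounds:
- compound 1, `C[S+]([O-])c1c(F)c(N)c2c(=O)cc(-c3ccc(N)c(F)c3)oc2c1F`: > 100000 nM
- compound 2, `[N-]=[N+]=Nc1c(F)c(N)c2c(=O)cc(-c3ccc(N)c(F)c3)oc2c1F`: 1200 nM

In a functional assay on HeLa cells (Homo sapiens) for cytotoxicity, read by neutral red uptake, with a stated time of 3 days (a higher number here means a weaker inhibitor, a lower number a stronger inhibitor), compound 1 gives > 100000 nM, which is a limit of the assay and not a number. Among the measured compounds shown here, compound 2 gives 1200 nM in this assay, the only number among the two values shown, the other being (the limit of > 100000 nM in this assay, at which 1 of the 2 values shown sits). The change an at least 83-fold lower number from compound 1 to compound 2 (1.92 log units; beyond the scatter) is therefore known only as a lower bound, but it shows that this position of the shared core is sensitive to the group placed there.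

Compound 3, `Nc1ccc(-c2cc(=O)c3c(N)c(F)c(N)c(F)c3o2)cc1F`, has not yet been measured. It differs from compound 2 in one place: amino in place of azido on an aromatic carbon. For the measured compounds named here, the only measured step concerns the same position but exchanges different groups, so it bears on this change only indirectly and sets no clear direction. A step of moderate size in this assay, in either direction, is expected for the change a 2.5-fold higher number from compound 2 to compound 3 (0.40 log units; beyond the scatter). Compound 3 is accordingly estimated at 3000 nM in this assay, with a likely range from 600 nM to 15000 nM.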

Compound 3, half-maximal inhibitory concentration: 19000 nM
The estimate for compound 3 lay 6.3-fold (0.80 log units) below the measured number, outside the stated range (above it).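

Replacing azido with amino on this aromatic carbon, ortho to two fluoro groups, has a large effect of its own in this assay: a 16-fold higher number from compound 2 to compound 3 (1.20 log units; beyond the scatter). This shows that the high potency of compound 2 among these compounds is not shared by every small nitrogen group at this position, as the amino group, with a single nitrogen atom, gives up much of it. The value of compound 1 is a limit of the assay and not a number: the limit of > 100000 nM in this assay, at which 1 of the 3 values shown sits.

Even so, the amino group is still better than the sulfur-bearing group of the first compound, as an at least 5.2-fold lower number from compound 1 to compound 3 (0.72 log units; beyond the scatter) shows, although this step is only a bound. The order at this position in this assay therefore runs from azido as the strongest, through amino, to the sulfur-bearing group as the weakest.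

The compounds shown do not reveal which feature of the azido group sets it apart, so the gap has no stated cause. Where a nitrile, a methoxy group, a dimethylamino group or a carboxylic acid would fall in this order at the same position also remains open.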